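This account rests on a few compounds, and the source may have more. Where it says the series, first, only, none or still open, it means among the compounds named here.

In an ADME assay on BJ cells (Homo sapiens) for cytotoxicity, with a stated time of 72 h (a lower number here means that less compound is needed, a higher number that more compound is needed for the effect), compound 1 (`CCOc1ccc(/C=C/[C@@](C)(/C=C/c2ccc(O)cc2)CCC=C(C)C)cc1`) gives > 36600 nM, which is a limit and not a number. Compound 2 (`CC(C)=CCC[C@@](C)(/C=C/c1ccc(C)cc1)/C=C/c1ccc(O)cc1`) gives > 36600 nM, also a limit and not a number. Both values in the series sit at the same point: the limit of > 36600 nM in this assay, at which 2 of the 2 values shown sit. For the measured compounds named here, the only measured step, a step that the two limits leave unreadable from compound 1 to compound 2, therefore offers no size to carry forward.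

Compound 3 (`CC(C)=CCC[C@](C)(/C=C/c1ccc(O)cc1)/C=C/c1cccc(F)c1`) changes one group of compound 2, on a double-bonded chain carbon bound to a double-bonded chain carbon: 3-fluorophenyl in place of 4-methylphenyl on a double-bonded chain carbon bound to a double-bonded chain carbon. Going by the values given here, no measured step covers this exchange.

The reference point remains compound 2 with its limit of > 36600 nM, so no readable change is expected in this assay. The expected step is a number no higher from compound 2 to compound 3 (the limit leaves the size open), with no move beyond the scatter anticipated. For compound 3 the estimated value is 36600 nM, with an expected range of 20000 nM to 50000 nM, and a report at the same limit is the likeliest outcome.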

Compound 3, half-maximal effective concentration: > 36600 nM
Compound 3 was reported as a limit (the forecaster's own chance of this, stated with the estimate: 85%); the middle value sits exactly at the limit.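

No step among compound 1, compound 2 and compound 3 can be read, since each result is only a limit and not a number: the limit of > 36600 nM in this assay, at which 3 of the 3 values shown sit.

The compounds shown leave open which change on the shared core, if any, would give a readable value.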